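This account rests on a few compounds, and the source may have more. Where it says the series, first, only, none or still open, it means among the compounds named here.

Of the compounds shown here, three that share one core have been tested in an assay on isolated protein for inhibition of 2-Hydroxyacid oxidase 2 (Rattus norvegicus), tested at 10 uM; a higher number here means a stronger effect of the compound at the concentration tested, a lower number a weaker effect. Compound 1 `Cc1n[nH]c(C(=O)O)c1Cc1cccc(C(=O)O)c1` gives 60%, compound 2 `Cc1n[nH]c(C(=O)O)c1Cc1ccc(C(F)(F)F)cc1` gives 71%, and compound 3 `Cc1n[nH]c(C(=O)O)c1CCc1ccc(F)cc1` gives 81%. Compound 2 thus holds the second highest of the three numbers; its value sits within the usual scatter of compound 3, while compound 1 lies beyond the scatter below it. Compound 4 `Cc1n[nH]c(C(=O)O)c1Cc1ccc(C(=O)O)cc1` has not yet been measured. It differs from compound 2 in one place: carboxy in place of trifluoromethyl on an aromatic carbon. For the measured compounds named here, no measured pair shows this change directly, yet compound 1, which also carries a carboxy on its aromatic ring, gives 60%, so in this assay a moderate downward step is expected. Compound 4 is expected to give 58%, between 40% and 76%, an expected a number 13 percentage points lower from compound 2 to compound 4 (beyond the scatter).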

Compound 4, a percentage reported as inhibition, at one concentration (the size of the read-out at that concentration, not a potency): 69%
For compound 4 the middle estimate is 11 percentage points below the measured one; measured number inside the range.
By their numbers in this assay, from the lowest: compounds 1, 4, 2 and 3 (each within the scatter of the next, the first and the last beyond it).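

Placed on an aromatic carbon para to a large group, carboxy in place of trifluoromethyl gives a number 2 percentage points lower from compound 2 to compound 4 (within the scatter) in this assay. At this position, then, the read-out does not separate the two groups, even though carboxy adds a hydrogen-bond donor and a hydrogen-bond acceptor that trifluoromethyl lacks. Nothing measured here explains this result. Open, as far as these compounds go, is whether an amine or a methyl ester on the same carbon would also leave the read-out within the scatter of compound 2.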